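From Amide Back to Urea: Estimating Compound 4

The source may hold more compounds than are shown below. What is called first, only, known or untested is meant among the compounds shown, and "the series" means these compounds.

Measured compounds:
compound 1, `CNC(=O)c1cc(Oc2ccc3nc(NC(=O)Nc4ccc(Cl)cc4Cl)sc3c2)ccn1`: 93.6%
compound 2, `CNC(=O)c1cc(Oc2ccc3nc(NC(=O)c4cccc(F)n4)sc3c2)ccn1`: 55.5%
compound 3, `CNC(=O)c1cc(Oc2ccc3nc(NC(=O)c4ccc(Cl)cc4Cl)sc3c2)ccn1`: 64.4%

In a functional assay on HCT-116 cells (Homo sapiens) for inhibition, read by MTT assay, with a stated time of 2 days, tested at 100 uM (a lower number here means less inhibition of growth, a higher number more inhibition of growth at the concentration tested), compound 3 holds the second highest of the three numbers. Its nearest neighbour is within the scatter, a number 8.9 percentage points higher from compound 2 to compound 3 (within the scatter), while the furthest is beyond it, a number 29.2 percentage points lower from compound 1 to compound 3 (beyond the scatter).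

Compound 4, `CNC(=O)c1cc(Oc2ccc3nc(NC(=O)Nc4ccc(F)cc4)sc3c2)ccn1`, differs from compound 3 in one place: (4-fluorophenyl)amino in place of 2,4-dichlorophenyl on a carbonyl carbon. Of the measured steps only one bears on this, a number 29.2 percentage points lower from compound 1 to compound 3 (beyond the scatter), where the amino group was taken off the carbonyl carbon with a modest loss. For the measured compounds named here, compound 4 puts an amino group back, though with 4-fluorophenyl rather than 2,4-dichlorophenyl, and no measured pair informs that aryl swap. A modest rise is therefore expected, a number 15.6 percentage points higher from compound 3 to compound 4 (beyond the scatter). Compound 4 is estimated at 80%, between 60% and 95%.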

Compound 4, percent growth inhibition at one concentration: 83.8%
Estimate against measurement, compound 4: 3.8 percentage points below; the range from low to high includes it.
By their numbers in this assay, from the lowest: compounds 2 and 3 (each within the scatter of the next); then compounds 4 and 1 (each within the scatter of the next).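

In this assay, (4-fluorophenyl)amino on the carbonyl carbon outdoes both aryl amides, a number 19.4 percentage points higher from compound 3 to compound 4 (beyond the scatter) and a number 28.3 percentage points higher from compound 2 to compound 4 (beyond the scatter), so the higher level of compound 1 does not depend on 2,4-dichlorophenyl. Changing that ring to 4-fluorophenyl on the amide-type nitrogen stays within the scatter, a number 9.8 percentage points lower from compound 1 to compound 4 (within the scatter). Nothing available explains these differences. The compounds shown leave open whether an aromatic ring is needed on that nitrogen at all, for instance whether a cyclohexyl ring there would hold the same level.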